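A few compounds are considered here, and "the series" means these few. Any claim that something is new, unique, unknown or untested is made for them only; others in the source may bear on it.

Three compounds share an arylpiperazine linked through a four-carbon chain to an imide or amide. Compound 1 `COc1ccc(OC)c(N2CCN(CCCCN3C(=O)c4ccccc4C3=O)CC2)c1` gives 15 nM in an assay on frontal cortex for binding affinity to Adrenergic receptor alpha-1 (Rattus norvegicus), read by radioligand binding; on this read-out higher numbers stand for weaker inhibition and lower numbers for stronger inhibition; compound 2 `O=C1c2ccccc2C(=O)N1CCCCN1CCN(c2ccccc2[N+](=O)[O-])CC1` gives 25 nM, and the change a 1.7-fold higher number from compound 1 to compound 2 (0.22 log units; within the scatter) does not exceed the scatter. Compound 3 `COc1ccccc1N1CCN(CCCCNC(=O)c2ccc([N+](=O)[O-])cc2)CC1` gives 14 nM, which sits within the scatter of both other numbers. Compound 4 `CCCCC(=O)NCCCCN1CCN(c2ccccc2OC)CC1` carries butyl in place of 4-nitrophenyl on a carbonyl carbon. Going by the values given here, no measured step touches this carbonyl substituent; the only step on record, a 1.7-fold higher number from compound 1 to compound 2 (0.22 log units; within the scatter), concerns the aryl group on the piperazine nitrogen and stayed within the scatter. Among the compounds with values here, with no direct precedent, the loss of the aromatic amide group is expected to cost some affinity, so compound 4 is estimated at 60 nM (range 15 nM to 250 nM), a step of a 4.3-fold higher number from compound 3 to compound 4 (0.63 log units; beyond the scatter) from compound 3 that is expected but uncertain.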

Compound 4, inhibition constant: 84 nM
Beside the measured number, compound 4's estimate is 1.4-fold (0.15 log units) below it, within the range that was stated.
By their numbers in this assay, from the lowest: compounds 3, 1 and 2 (each within the scatter of the next); then compound 4.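

In this assay, going by these compounds alone, butyl in place of 4-nitrophenyl on a carbonyl carbon gives a 6.0-fold higher number from compound 3 to compound 4 (0.78 log units; beyond the scatter), the first step to go beyond the scatter. Within the data shown here, the carbonyl substituent is therefore a position where the number responds, unlike the aryl group on the piperazine nitrogen in the one earlier step, though compound 4 still reads 84 nM. No evidence at hand bears on the reason for this step. From the compounds shown here alone, whether a plain phenyl or a cyclohexyl group at this carbonyl carbon would read closer to compound 3 or to compound 4 remains open. So does the effect of a longer chain in place of butyl.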